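The compounds below may be only part of what the source reports. "The series", "measured", "known", "first", "only" and "open" are said of these compounds alone.

Working notes on the series in an assay on HEK293 cells for positive allosteric modulation of metabotropic glutamate receptor 2 (Rattus norvegicus), read by thallium flux, with a stated time of 2.5 min; on this read-out higher numbers stand for larger maximal responses and lower numbers for smaller maximal responses.

Of the compounds shown here, three have numbers so far. Compound 1 `Cc1c(OCCCCOCOc2ccc(C(=O)O)cc2)ccc(C(=O)CC2CCCC2)c1O` gives 95.4% in this assay. Compound 2 `CCCC(=O)c1ccc(OCCCCOc2cccc(C(=O)O)c2C)c(C)c1O` gives 82.4%. Compound 3 `Cc1c(OCCCCOc2ccc(F)c(C(=O)O)c2)ccc(C(=O)CC2CCCC2)c1C` gives 14.6%. Compound 2 thus stands second highest of the three: the nearest number is that of compound 1, which lies higher by a margin beyond the scatter, and the furthest is that of compound 3, which lies far lower, again beyond the scatter.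

Compound 4 `CC(=O)c1ccc(OCCCCOc2cccc(C(=O)O)c2C)c(C)c1O` is the next member, not yet measured. Against compound 2 the change is hydrogen in place of ethyl on a saturated chain carbon bound to a carbonyl carbon. Going by the values given here, no pair of measured compounds differs by this change alone, so nothing in the numbers so far shows how shortening the chain on the carbonyl side plays out. The chain is short in both, and the rest of the structure is kept, so only a modest step is expected, more likely downward than upward, and quite possibly none beyond the scatter.

Compound 4 is expected to give about 74% in this assay, between 50% and 95%, which means an estimated step of a number 8.4 percentage points lower from compound 2 to compound 4 (within the scatter).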

Compound 4, largest response reached (reported as percent of maximum), in percent of the reference or control that the assay uses: 79.2%
Beside the measured number, compound 4's estimate is 5.2 percentage points below it, and the stated range covers the measured number.
By their numbers in this assay, from the lowest: compound 3; then compounds 4 and 2 (each within the scatter of the next); then compound 1.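

In this assay, going by these compounds alone, the change from propylcarbonyl to acetyl gives a number 3.2 percentage points lower from compound 2 to compound 4 (within the scatter) and is the first comparison in which only one place differs. In this pair, hydrogen in place of ethyl on a saturated chain carbon bound to a carbonyl carbon does not separate the two compounds, and the ethyl is not required for a large maximal response, since compound 4 gives 79.2% here. No measurement at hand bears on why the two compounds read alike.

From the compounds shown here alone, whether a longer chain such as hexyl, or an amine on that same chain carbon, would read the same way remains open. Also open, going by these compounds, is whether this change would give a similar step on the cores of compound 1 and compound 3, which differ from compound 2 in more than one place.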